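Swapping thiomorpholine for morpholine on a thiosemicarbazide

A few compounds are considered here, and "the series" means these few. Any claim that something is new, unique, unknown or untested is made for them only; others in the source may bear on it.

Compound 1 `Cc1cccc(/C(N)=N/NC(=S)N2CCSCC2)n1` and compound 3 `N/C(=N\NC(=S)N1CCSCC1)c1ccc(F)cn1` share a thiomorpholin-4-yl group on a thiocarbonyl carbon but differ in their cores; that difference between the two cores is not broken down here. Compound 2 `Cc1cccc(/C(N)=N/NC(=S)N2CCOCC2)n1` and compound 4 `N/C(=N\NC(=S)N1CCOCC1)c1ccc(F)cn1` are their morpholine counterparts.

In a functional assay on MCF7 cells (Homo sapiens) for cytotoxicity, read by MTT assay, with a stated time of 72 h (on this read-out higher numbers stand for weaker inhibition and lower numbers for stronger inhibition), compound 1 gives only a limit, > 100000 nM. Compound 2 gives 21500 nM in this assay. The step of an at least 4.6-fold lower number from compound 1 to compound 2 (0.66 log units; beyond the scatter) comes from morpholin-4-yl in place of thiomorpholin-4-yl on a thiocarbonyl carbon, and its size rests on (the limit of > 100000 nM in this assay, at which 1 of the 3 values shown sits). Compound 3 gives 21400 nM in this assay.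

Compound 4 carries the same change, (morpholin-4-yl in place of thiomorpholin-4-yl on a thiocarbonyl carbon), at an identical place. The expected step is a 2.7-fold lower number from compound 3 to compound 4 (0.43 log units; beyond the scatter), because the same exchange earlier gave an at least 4.6-fold lower number from compound 1 to compound 2 (0.66 log units; beyond the scatter). Compound 4 is therefore estimated at 8000 nM, most likely between 2500 nM and 25000 nM.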

Compound 4, half-maximal inhibitory concentration: 22100 nM
Compound 4: the middle estimate sits 2.8-fold (0.44 log units) below what was measured, and the stated range covers the measured number.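

In this assay putting morpholin-4-yl in place of thiomorpholin-4-yl on the thiocarbonyl carbon gives a 1.0-fold higher number from compound 3 to compound 4 (0.01 log units; within the scatter) and so makes no real difference on this core. The change therefore did not carry over unchanged from one core to the other: the same change on two cores in this assay, an at least 4.6-fold lower number (0.66 log units; beyond the scatter) from compound 1 to compound 2 and a 1.0-fold higher number (0.01 log units; within the scatter) from compound 3 to compound 4, at least 4.8-fold (0.68 log units) apart, beyond the scatter of two such steps. The earlier step also rests on a limit and not on a number, so its true size stays unknown, and two cores alone cannot show why the steps part: the limit of > 100000 nM in this assay, at which 1 of the 4 values shown sits.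

Still open, as far as these compounds go, is how this exchange behaves on further cores. From the compounds shown here alone, it is also open whether another ring on the thiocarbonyl carbon, such as piperidin-1-yl, or an open-chain dimethylamino group would follow either step.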